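A few compounds are considered here, and "the series" means these few. Any claim that something is new, unique, unknown or untested is made for them only; others in the source may bear on it.

In a functional assay on the whole organism for inhibition, with Rattus norvegicus as the target, read by paw edema, with stated times of 1 h and 3 h (a higher number here means that more compound is needed for the effect, a lower number that less compound is needed), compound 2 (`O=C(O)CO/N=C/c1ccc(Cl)cc1`) gives 45 mg/kg, compound 3 (`O=C(O)CO/N=C/c1ccc(Br)cc1`) gives 46 mg/kg and compound 1 (`C/C(=N\OCC(=O)O)c1ccc(Cl)c(Cl)c1`) gives 65 mg/kg. Compound 2 lies within the scatter of both. Compound 4 (`OCCO/N=C/c1ccc(Cl)cc1`) carries hydroxymethyl in place of carboxy on a saturated chain carbon bound to an oxygen on an unsaturated carbon. For the measured compounds named here, the only measured step, a 1.0-fold higher number from compound 2 to compound 3 (0.01 log units; within the scatter), swaps bromo for chloro on an aromatic carbon. Going by the values given here, it stays within the scatter but does not touch this place, and no measured compound lacks the carboxy group. The size of this change is therefore unknown, and no step beyond the scatter is expected in this assay. The estimate means a 1.3-fold higher number from compound 2 to compound 4 (0.12 log units; within the scatter), an expected step. For compound 4 the estimated value is 60 mg/kg, with an expected range from 25 mg/kg to 150 mg/kg.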

Compound 4, dose for half-maximal effect: 90 mg/kg
The estimate for compound 4 lay 1.5-fold (0.18 log units) below the measured number; low and high end bracket the measured number.
By their numbers in this assay, from the lowest: compounds 2, 3, 1 and 4 (each within the scatter of the next).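

In this assay, for the compounds shown here, this is the first measured change at the saturated chain carbon bound to an oxygen on an unsaturated carbon, where earlier compounds all keep carboxy. Hydroxymethyl in place of carboxy (a 2.0-fold higher number from compound 2 to compound 4 (0.30 log units; within the scatter)) stays within the scatter, so this pair gives no sign that the read-out depends on carboxy. No available data bear on the reason for this result.

Still open, going by these compounds, is whether an amine or a longer chain at this place also stays within the scatter. On these data alone, whether the same change holds with bromo on the aromatic carbon also remains open.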